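This account rests on a few compounds, and the source may have more. Where it says the series, first, only, none or still open, it means among the compounds named here.

Compound 1 `Cc1cccc(-c2nc3ccc(C)cc3c(=O)[nH]2)c1` was examined in an assay on isolated protein for inhibition of DNA topoisomerase 1 (Homo sapiens), with a stated time of 30 min, tested at 20 uM (on this read-out higher numbers stand for a stronger effect at the one concentration tested and lower numbers for a weaker effect), where compound 1 gives 12.7%. Among the compounds with values here, that is the only number in this small set: compound 2 `Cc1ccc2nc(-c3cccc4ccccc34)[nH]c(=O)c2c1` belongs to the same series, but in this assay compound 2 gives "not determined" (no result reported), so compound 1 stands alone with a modest read-out. Compound 3 `Cc1ccc2nc(-c3cccc(OC(F)(F)F)c3)[nH]c(=O)c2c1` has not been measured. It differs from compound 1 in a single place: trifluoromethoxy in place of methyl on an aromatic carbon. The trifluoromethoxy group takes the position of the methyl on an aromatic carbon of a six-membered aromatic ring of carbon only. Within the data shown here, no measured pair in this set shows what such a change does to the read-out, so there is no basis for a direction. The expected step is small, a number 1.3 percentage points higher from compound 1 to compound 3 (within the scatter), within the usual scatter and with no direction favoured. Compound 3 is therefore estimated at 14% in this assay, within a range from 0% to 35%.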

Compound 3, a percentage reported as inhibition, at one concentration (the size of the read-out at that concentration, not a potency): 0%
Beside the measured number, compound 3's estimate is 14 percentage points above it, within the range that was stated.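

In this assay, within the data shown here, replacing methyl with trifluoromethoxy on an aromatic carbon of the six-membered aromatic ring of carbon only gives a number 12.7 percentage points lower from compound 1 to compound 3 (beyond the scatter) and provides the first readable step in this set. It shows that the read-out responds to the group at this place, and that this larger group, with five heavy atoms against one, does not retain the modest effect of compound 1. Nothing measured here bears on the cause of this loss.

Only one replacement at this place is shown, so a single step cannot separate the effect of the group's size from that of its oxygen or fluorine atoms. A methoxy group, an amine or a carboxylic acid here remains an open case, as does whether any group at this place could raise the read-out above that of compound 1.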